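A few compounds are considered here, and "the series" means these few. Any claim that something is new, unique, unknown or untested is made for them only; others in the source may bear on it.

Measured compounds:
- compound 1 `CC(C)(C)OC(=O)CN(Cc1ccc(Cl)cc1)Cc1cnc[nH]1`: "not determined" (no result reported)
- compound 2 `CC(C)(C)OC(=O)CN(Cc1ccccc1)Cc1ccc([N+](=O)[O-])s1`: "not determined" (no result reported)
- compound 3 `CC(C)(C)OC(=O)N1CCC(CN(Cc2ccc(Cl)cc2)Cc2ccc([N+](=O)[O-])s2)C1`: 1800 nM

For the measured compounds named here, in a functional assay on HEK293 cells for agonist activity at nuclear receptor subfamily 1 group D member 1 (Homo sapiens), read by a luciferase reporter, with a stated time of 24 h (on this read-out lower numbers stand for an effect already at smaller amounts and higher numbers for an effect only at larger amounts of compound), compound 3 gives 1800 nM, the only number so far; compound 1 and compound 2 carry no result in this assay. Compound 4 `O=[N+]([O-])c1ccc(CN(Cc2ccc(Cl)cc2)CC2CCN(S(=O)(=O)Cc3ccccc3)C2)s1` is the next entry, and it differs from compound 3 in one place: benzylsulfonyl in place of tert-butoxycarbonyl on an amine nitrogen in a ring. Going by the values given here, no step between measured compounds is available, so the size of the change in this assay cannot be read off any pair already in hand. A step of moderate size toward lower numbers is expected, as a 1.8-fold lower number from compound 3 to compound 4 (0.26 log units; within the scatter), though a result within the scatter of compound 3 would not be surprising. For compound 4 the estimate in this assay is 1000 nM, with a range from 300 nM to 4000 nM.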

Compound 4, half-maximal effective concentration: 630 nM
Compound 4: the middle estimate sits 1.6-fold (0.20 log units) above what was measured; the measured number falls inside the stated range.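

In this assay the amine nitrogen in the ring gives its first readable step: benzylsulfonyl in place of tert-butoxycarbonyl gives a 2.9-fold lower number from compound 3 to compound 4 (0.46 log units; beyond the scatter) and so goes beyond the usual scatter. The position therefore accepts the larger group, with its six-membered aromatic ring, without loss on this read-out. Nothing at hand explains the step.

On these data alone, whether the sulfonyl link or the aromatic ring carries the step stays open. A methylsulfonyl group on the same nitrogen would separate the two, and a single pair cannot show a trend at this position.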